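The compounds below may be only part of what the source reports. "The series", "measured", "known", "first", "only" and "open" are said of these compounds alone.

Working notes on the series. Compound 1 `O=C1O[C@H]([C@@H](O)Cn2cc(-c3cc(F)cc(F)c3)nn2)C(OCc2ccccc2)=C1OCc1ccccc1` stands at 62400 nM in a functional assay on CFPAC-1 cells (Homo sapiens) for antiproliferative activity, read by MTT assay, with a stated time of 72 h; on this read-out lower numbers stand for stronger inhibition and higher numbers for weaker inhibition. Compound 2 `O=C1O[C@H]([C@@H](O)Cn2cc(CNS(=O)(=O)c3ccc(Cl)cc3F)nn2)C(OCc2ccccc2)=C1OCc1ccccc1` gives 58200 nM in this assay, and the gap between the two numbers lies within the usual scatter. Compound 3 `COc1ccc(-c2cn(C[C@H](O)[C@H]3OC(=O)C(OCc4ccccc4)=C3OCc3ccccc3)nn2)cc1` remains to be measured in this assay. It differs from compound 1 in one place: 4-methoxyphenyl in place of 3,5-difluorophenyl on an aromatic carbon. Going by the values given here, no step between measured compounds is available to scale this change, and both measured numbers show only weak inhibition. For compound 3 the step of a 1.0-fold lower number from compound 1 to compound 3 (0.02 log units; within the scatter) is expected to stay within the scatter, with no clear direction. Compound 3 is therefore estimated at 60000 nM, in the range 25000 nM to 150000 nM.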

Compound 3, half-maximal inhibitory concentration: 26000 nM
Compound 3: the middle estimate sits 2.3-fold (0.36 log units) above what was measured; measured number inside the range.
By their numbers in this assay, from the lowest: compound 3; then compounds 2 and 1 (each within the scatter of the next).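

In this assay, the step to 4-methoxyphenyl in place of 3,5-difluorophenyl gives a 2.4-fold lower number from compound 1 to compound 3 (0.38 log units; beyond the scatter), so the number responds, modestly, to the aryl group on this aromatic carbon of the five-membered aromatic ring with 3 nitrogen. The change keeps the heavy-atom count of the group and brings in one hydrogen-bond acceptor. No measurement at hand accounts for the step. From the compounds shown here alone, whether the methoxy group or the absence of the two fluorines matters remains open. Unsubstituted phenyl or 4-hydroxyphenyl at this carbon would help to separate the two.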